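The source may hold more compounds than are shown below. What is called first, only, known or untested is meant among the compounds shown, and "the series" means these compounds.

Compound 1, `c1ccc(Cn2ccc3nc(-c4ccccc4)nc-3c2)cc1`. In an ADME assay on MDBK cells (Bos taurus) for cytotoxicity (on this read-out higher numbers stand for lower toxicity in this test and lower numbers for higher toxicity in this test), compound 1 gives > 100000 nM, which is a limit of the assay rather than a number.
Compound 2, `Cc1ccc(Cn2ccc3nc(-c4ccccc4)nc-3c2)cc1`. In this assay compound 2 gives > 100000 nM, again a limit.
Compound 3, `Clc1cccc(Cn2ccc3nc(-c4ccccc4)nc-3c2)c1`. In this assay compound 3 gives > 100000 nM, also a limit.

Compound 3 therefore stands only at a limit, and so do the two other measured compounds: every value shown sits at the limit of > 100000 nM in this assay, at which 3 of the 3 values shown sit. The steps between the measured compounds are a step that the two limits leave unreadable from compound 1 to compound 2, a step that the two limits leave unreadable from compound 1 to compound 3 and a step that the two limits leave unreadable from compound 2 to compound 3; none of them can be read, since both ends are limits.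

Compound 4, `Clc1ccc(Cn2ccc3nc(-c4ccccc4)nc-3c2)cc1Cl`, is not yet measured. It differs from compound 3 by chloro in place of hydrogen on an aromatic carbon; cut one bond further out, the change reads 3-chlorophenyl to 3,4-dichlorophenyl. Within the data shown here, the steps that bear on it, a chloro or a methyl entering the same benzyl ring, left no readable size, so no step beyond the scatter in this assay can be expected in either direction. Compound 4 is therefore expected at the same limit, an estimate of 100000 nM, between 40000 nM and 300000 nM, meaning an expected step of a number no higher from compound 3 to compound 4 (the limit leaves the size open).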

Compound 4, half-maximal cytotoxic concentration: 71000 nM
The estimate for compound 4 lay 1.4-fold (0.15 log units) above the measured number, within the range that was stated.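

Among these compounds, the 3,4-dichlorophenyl group of compound 4, with its new chloro para to a large group and ortho to a chloro group, gives the first reading in this assay that is a number and not a limit. The steps that can be read are an at least 1.4-fold lower number from compound 3 to compound 4 (0.14 log units; that floor lies within the scatter) and an at least 1.4-fold lower number from compound 2 to compound 4 (0.14 log units; that floor lies within the scatter) and an at least 1.4-fold lower number from compound 1 to compound 4 (0.14 log units; that floor lies within the scatter) and none of these floors goes beyond the scatter, so this change shows no clear rise in toxicity in this test. The true size of each step stays unknown because the other end of each is a limit: the limit of > 100000 nM in this assay, at which 3 of the 4 values shown sit.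

On these data alone, whether a group other than chloro at this place, such as an amine or a carboxylic acid, would give a step beyond the scatter remains open. So does the effect of a third chloro on this ring.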